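Changing the amide substituent of compound 2

The source may report more compounds than this note shows. Statements on the series, on what has been measured and on what is new or still open speak of the compounds shown alone.

Within the data shown here, in a functional assay on Caco-2 cells (Homo sapiens) for antiproliferative activity, read by MTT assay, with a stated time of 48 h (on this read-out lower numbers stand for stronger inhibition and higher numbers for weaker inhibition), compound 1 `CCn1c(C(=O)NCCN(C)C)ccc1C(CC)(CC)c1ccc(OCCC(O)(CC)CC)c(C)c1` gives 1140 nM, while compound 2 `CCn1c(C(=O)NC(CC(=O)O)C(=O)OC)ccc1C(CC)(CC)c1ccc(OCCC(O)(CC)CC)c(C)c1` gives 25200 nM, the higher of the two numbers so far. Compound 3 `CCn1c(C(=O)NC(C)CO)ccc1C(CC)(CC)c1ccc(OCCC(O)(CC)CC)c(C)c1` changes the same place, on an amide-type nitrogen, with 1-(hydroxymethyl)ethyl entering: a group of 4 heavy atoms (3 carbon, 1 oxygen; no ring) in place of a group of 9 heavy atoms (5 carbon, 4 oxygen; no ring), on an amide-type nitrogen. Among the measured compounds shown here, the only measured step bearing on this change is a 22-fold higher number from compound 1 to compound 2 (1.34 log units; beyond the scatter), a large one that also concerns the group on this nitrogen. For the measured compounds named here, that single step shows that this assay responds to changes here, but no measured compound carries the new group, so the size of the next step remains uncertain. A moderate step towards a lower number is expected, smaller than the measured one. The estimated change is a 4.2-fold lower number from compound 2 to compound 3 (0.62 log units; beyond the scatter). Compound 3 is expected at 6000 nM, within an estimated range of 1800 nM to 20000 nM.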

Compound 3, half-maximal inhibitory concentration: > 50000 nM
Compound 3 was reported as a limit; the forecaster's own chance of this, stated with the estimate: 5%; at least 8.3-fold (0.92 log units) between middle value and limit.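

Compound 3 is reported in this assay only as a limit, not as a number: > 50000 nM. The smaller group on the amide-type nitrogen brings no separated gain over compound 2, and the order of the two remains unsettled: an at least 1.9-fold higher number from compound 2 to compound 3 (0.29 log units; that floor lies within the scatter). The gap to the 2-(dimethylamino)ethyl compound is large, an at least 43-fold higher number from compound 1 to compound 3 (1.64 log units; beyond the scatter), so among the three compounds compound 1 alone stands clearly apart, with the lowest number, and neither group without the dimethylamino nitrogen comes near it.

Three compounds cannot show whether the dimethylamino group itself or the two-carbon chain carrying it sets this difference. On these data alone, a primary amine, a diethylamino group or a 3-(dimethylamino)propyl chain on this nitrogen would test that, and the real value of compound 3 stays open.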